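A few compounds are considered here, and "the series" means these few. Any claim that something is new, unique, unknown or untested is made for them only; others in the source may bear on it.

Measured compounds:
- compound 1, `CN1CCN(c2nc(Cl)nc3c2ncn3Cc2ccc(C(=O)Nc3ccccc3N)cc2)CC1`: 75%
- compound 2, `Nc1ccccc1NC(=O)/C=C/c1ccc(Cn2cnc3c(NCc4ccccc4)nc(Cl)nc32)cc1`: 37.7%

Both compounds were tested in a functional assay on HepG2 cells (Homo sapiens) for antiproliferative activity, read by CCK-8 assay, with a stated time of 72 h, tested at 8 uM; on this read-out higher numbers stand for a stronger effect at the one concentration tested and lower numbers for a weaker effect. Compound 1 reaches 75% in this assay, the higher of the two numbers. Compound 2, which carries a different group on the shared core and a longer link to the amide, gives 37.7% in this assay, and the gap between the two values is beyond the scatter of repeated measurements. For the measured compounds named here, no pair of measured compounds differs in only one place, so no single structural change has been tied to a measured step.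

Compound 3, `Nc1ccccc1NC(=O)c1ccc(Cn2cnc3c(Nc4cccc(Cl)c4)nc(Cl)nc32)cc1`, has not yet been measured. It differs from compound 1 in one place: (3-chlorophenyl)amino in place of 4-methylpiperazin-1-yl on an aromatic carbon. Because compound 1 stands at 75% and compound 2, with an aromatic amine on the same carbon, only at 37.7%, a step from compound 1 to compound 3 is expected to be a modest decrease, though it could also stay within the scatter, so that a number 15 percentage points lower from compound 1 to compound 3 (beyond the scatter) is estimated. Compound 3 is therefore expected to give about 60% in this assay, between 35% and 80%.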

Compound 3, a percentage reported as inhibition, at one concentration (the size of the read-out at that concentration, not a potency): 66.7%
For compound 3 the middle estimate is 6.7 percentage points below the measured one; the measured number falls inside the stated range.
By their numbers in this assay, from the lowest: compound 2; then compounds 3 and 1 (each within the scatter of the next).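

For the compounds shown here, this is the first comparison in which only one group on the shared core changes. In this assay, putting (3-chlorophenyl)amino in place of 4-methylpiperazin-1-yl on this aromatic carbon gives a number 8.3 percentage points lower from compound 1 to compound 3 (within the scatter) so the two groups cannot be told apart by this read-out, even though one is a non-aromatic ring with two ring nitrogens and the other is an aromatic carbon ring joined through an amino nitrogen. The read-out at this carbon therefore does not depend on keeping the 4-methylpiperazin-1-yl group in this pair, and no available measurement bears on why the two groups give such similar results.

From the compounds shown here alone, what remains open is whether this tolerance extends to other groups on the same carbon, such as morpholin-4-yl, a plain amino group or an unsubstituted phenylamino group, the last of which would show whether the chlorine on the aromatic ring contributes anything. Going by these compounds, since the read-out comes from one concentration in one cell line, how compound 1 and compound 3 compare at other concentrations, or in other cell lines, also stays open.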